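This account rests on a few compounds, and the source may have more. Where it says the series, first, only, none or still open, it means among the compounds named here.

In an assay on Sf9 cells for inhibition of serine/threonine-protein kinase 4 (Homo sapiens), read by luminescence and ADP-Glo, with a stated time of 1 h, in the presence of a further agent that is not named here (a higher number here means a weaker inhibitor, a lower number a stronger inhibitor), compound 2 `COc1ccccc1C1C(=O)N(C)c2cnc(Nc3ccc(S(N)(=O)=O)cc3)nc2N1C` gives 251 nM. Among the two measured compounds this is the higher number, but only by a small margin: compound 1 `CN1C(=O)C(CC2CC2)N(C)c2nc(Nc3ccc(S(N)(=O)=O)cc3)ncc21` gives 211 nM, and the step of a 1.2-fold higher number from compound 1 to compound 2 (0.08 log units; within the scatter) lies within the scatter, so the two cannot be separated on potency.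

Compound 3 `CN1C(=O)C(c2ccccc2C(F)(F)F)N(C)c2nc(Nc3ccc(S(N)(=O)=O)cc3)ncc21` is not yet measured. It differs from compound 2 in one place: trifluoromethyl in place of methoxy on an aromatic carbon, ortho to a large group. Going by the values given here, only one measured step touches this part of the molecule, and it exchanged the whole side group on the saturated ring carbon for a 2-methoxyphenyl without moving the number beyond the scatter. Among the compounds with values here, no measured step swaps one group for another on that phenyl ring, so there is no direct guide for what trifluoromethyl in place of methoxy will do in this assay. The expectation is therefore a number close to that of compound 2, with a wide range either way. Compound 3 is expected to give 280 nM in this assay, between 100 nM and 800 nM. This amounts to an expected step of a 1.1-fold higher number from compound 2 to compound 3 (0.05 log units; within the scatter).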

Compound 3, half-maximal inhibitory concentration: 56 nM
Compound 3: middle estimate off by 5.0-fold (0.70 log units), on the high side; the whole stated range lies above it.
By their numbers in this assay, from the lowest: compound 3; then compounds 1 and 2 (each within the scatter of the next).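

In this assay, the group on the phenyl ring proves to matter: trifluoromethyl in place of methoxy on this aromatic carbon, ortho to a large group, gives a 4.5-fold lower number from compound 2 to compound 3 (0.65 log units; beyond the scatter). This small exchange on the ring moves the number beyond the scatter, which the earlier exchange of the whole side group did not do. The comparison with the cyclopropylmethyl compound, a 3.8-fold lower number from compound 1 to compound 3 (0.58 log units; beyond the scatter), shows that an aromatic ring on the saturated ring carbon does not by itself give the lower number, since 2-methoxyphenyl could not be separated from cyclopropylmethyl, while 2-(trifluoromethyl)phenyl can. No measurement here explains the lower number.

The compounds shown carry only methoxy and trifluoromethyl on that phenyl ring, so it stays open whether a chlorine atom or a methyl group in the same place would give a number nearer that of compound 3 or that of compound 2, and whether trifluoromethyl elsewhere on the ring would keep the gain. Whether compound 3 also gives a lower number against other kinases is open as well.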